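Acetophenone series: saturated versus unsaturated long chains

This account rests on a few compounds, and the source may have more. Where it says the series, first, only, none or still open, it means among the compounds named here.

Measured compounds:
compound 1 `CCCCCCCCCCCCCCCCCCc1c(O)cc(O)c(C(C)=O)c1O` — 31000 nM
compound 2 `CCCCCCCC/C=C\CCCCCCCCOc1cc(O)cc(O)c1C(C)=O` — 32000 nM
compound 3 `CCCCCCCCCCCCCCCCCCOc1cc(O)cc(O)c1C(C)=O` — limit only, > 100000 nM

In a functional assay on HL-60 cells (Homo sapiens) for cytotoxicity, read by XTT assay, with a stated time of 72 h (on this read-out lower numbers stand for stronger inhibition and higher numbers for weaker inhibition), compound 1 gives 31000 nM and compound 2 gives 32000 nM; the two values lie within the scatter of each other. For compound 3 only a limit is reported in this assay, namely > 100000 nM (the limit of > 100000 nM in this assay, at which 1 of the 3 values shown sits). From compound 3 to compound 2 the change is dec-1-en-1-yl in place of decyl on a saturated chain carbon, eight bonds along the chain from an oxygen on an aromatic ring and the step is an at least 3.1-fold lower number from compound 3 to compound 2 (0.49 log units; beyond the scatter).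

Compound 4 `CCCCCCCC/C=C\CCCCCCCCc1c(O)cc(O)c(C(C)=O)c1O` is not yet measured and differs from compound 1 by dec-1-en-1-yl in place of decyl on a saturated chain carbon, eight bonds along the chain from an aromatic carbon. This is the same kind of change as between compound 3 and compound 2, though the place differs: there eight bonds along the chain from an oxygen on an aromatic ring, here eight bonds along the chain from an aromatic carbon. The difference between the core of compound 1 and the core of compound 3 is not broken down here.

The expected step is a 2.1-fold lower number from compound 1 to compound 4 (0.32 log units; beyond the scatter), taken as smaller than the earlier one since compound 1 starts from a measured number rather than a limit. Compound 4 is estimated at 15000 nM, with a likely range from 6000 nM to 35000 nM.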

Compound 4, half-maximal inhibitory concentration: > 100000 nM
Compound 4 was reported as a limit (the forecaster's own chance of this, stated with the estimate: 5%); at least 6.6-fold (0.82 log units) between middle value and limit.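

In this assay compound 4 gives > 100000 nM, which is a limit and not a number. The step is an at least 3.2-fold higher number from compound 1 to compound 4 (0.50 log units; beyond the scatter), so dec-1-en-1-yl in place of decyl does not carry from one core to the other with the same direction: the same change on two cores in this assay, an at least 3.1-fold lower number (0.49 log units; beyond the scatter) from compound 3 to compound 2 and an at least 3.2-fold higher number (0.50 log units; beyond the scatter) from compound 1 to compound 4, at least 10-fold (1.00 log units) apart, beyond the scatter of two such steps Both steps rest on limits, so their true sizes cannot be read, and nothing here explains the opposite directions: the limit of > 100000 nM in this assay, at which 2 of the 4 values shown sit.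

Open, as far as these compounds go, is whether this opposite behaviour persists with a longer chain or a shorter chain on either core. Also open, from the compounds shown here alone, is how either core responds to an amine or a carboxylic acid on the chain.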